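Dropping the Methyl: From Compound 2 to Compound 3

The source may hold more compounds than are shown below. What is called first, only, known or untested is meant among the compounds shown, and "the series" means these compounds.

Of the compounds shown here, two have been tested in a functional assay on HeLa cells (Homo sapiens) for cytotoxicity, read by MTT assay, with a stated time of 72 h, tested at 1 uM; a higher number here means more inhibition of growth at the concentration tested, a lower number less inhibition of growth. Compound 1 `N/C(=N\NC(=S)N1CCOCC1)c1ccccn1` gives 12.7%. Compound 2 `Cc1cccc(/C(N)=N/NC(=S)N2CCCC2)n1` gives 8.7%, the lower of the two numbers, though the gap to compound 1 lies within the scatter, so neither compound can be called weaker than the other. Compound 3 `N/C(=N\NC(=S)N1CCCC1)c1ccccn1` has not yet been measured. It differs from compound 2 in one place: hydrogen in place of methyl on an aromatic carbon. Among the measured compounds shown here, no pair of measured compounds isolates this change; compound 1 carries the ring without the methyl but also a different ring elsewhere in the molecule, so its value offers only a loose hint. In this assay a step no larger than the scatter is expected, in either direction. Compound 3 is therefore estimated at 10%, within 0% to 22%. The implied step a number 1.3 percentage points higher from compound 2 to compound 3 (within the scatter) is expected to stay small.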

Compound 3, percent growth inhibition at one concentration: 24.7%
Compound 3: middle estimate off by 14.7 percentage points, on the low side; the measured number lies above the stated range.
By their numbers in this assay, from the lowest: compounds 2 and 1 (each within the scatter of the next); then compound 3.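

In this assay, among the compounds shown here, hydrogen in place of methyl on an aromatic carbon next to the ring nitrogen gives a number 16 percentage points higher from compound 2 to compound 3 (beyond the scatter), so this position, which no earlier pair had isolated, does bear on the read-out. Compound 3 also shows that the group on the thiocarbonyl carbon counts, since pyrrolidin-1-yl in place of morpholin-4-yl gives a number 12 percentage points higher from compound 1 to compound 3 (beyond the scatter), and each of these two single changes therefore reaches beyond the scatter. No measurement at hand offers a reason for either step.

On these data alone, whether any group on that aromatic carbon would lower the number as methyl does, or whether this holds for methyl alone, remains open, and an ethyl, a methoxy or an amine there would speak to it. Also open, as far as these compounds go, is whether the methyl has the same effect when morpholin-4-yl sits on the thiocarbonyl carbon.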